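Swapping the Ester Cap of Compound 2

The source may report more compounds than this note shows. Statements on the series, on what has been measured and on what is new or still open speak of the compounds shown alone.

Of the compounds shown here, three have been measured in a functional assay on T47D cells (Homo sapiens) for antiproliferative activity, with a stated time of 72 h; on this read-out lower numbers stand for stronger inhibition and higher numbers for weaker inhibition. Compound 1 `OCC#CCSc1cnc2ccccc2c1SCC#CCCl` gives 5.3 ug/mL, compound 3 `OCC#CCSc1cnc2ccccc2c1[Se]CC#CCCl` gives 1.7 ug/mL, and compound 2 `CSc1cnc2ccccc2c1SCC#CCOC(=O)/C=C/c1ccccc1` gives 71.9 ug/mL, the highest number and therefore the weakest inhibitor of the three. For the measured compounds named here, the only step between compounds that differ in one place, a 3.1-fold lower number from compound 1 to compound 3 (0.49 log units; beyond the scatter), concerns a change at an aromatic carbon of the shared core and not the ester end. Compound 4 `CSc1cnc2ccccc2c1SCC#CCOC(=O)c1ccc(C(=O)O)cc1` differs from compound 2 by 4-carboxyphenyl in place of 2-phenylethenyl on a carbonyl carbon. Going by the values given here, no measured step touches this part of the molecule, so the data give no direction. Compound 4 is expected to stay near that level, at an estimated 70 ug/mL within a range of 25 ug/mL to 200 ug/mL. This expected step is a 1.0-fold lower number from compound 2 to compound 4 (0.01 log units; within the scatter), within the scatter.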

Compound 4, concentration for 50% inhibition: 36.1 ug/mL
Compound 4: middle estimate off by 1.9-fold (0.29 log units), on the high side; the measured number falls inside the stated range.
By their numbers in this assay, from the lowest: compound 3; then compound 1; then compounds 4 and 2 (each within the scatter of the next).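

In this assay, for the compounds shown here, the first measured step at the ester end of the molecule, 4-carboxyphenyl in place of 2-phenylethenyl on a carbonyl carbon, gives a 2.0-fold lower number from compound 2 to compound 4 (0.30 log units; within the scatter). That step lies within the scatter, so this exchange of caps does not separate the two compounds, even though it adds a carboxylic acid. No measurement shown here bears on why the two read alike. As far as these compounds go, whether a plain phenyl or a 4-aminophenyl group on the same carbonyl carbon would read differently remains open. So does the outcome of a short alkyl chain there.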